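The source may hold more compounds than are shown below. What is called first, only, known or untested is meant among the compounds shown, and "the series" means these compounds.

Cytotoxicity notes on the series. In an ADME assay on MT4 cells (Homo sapiens) for cytotoxicity, read by MTT assay, with a stated time of 4 days (a lower number here means that less compound is tolerated, a higher number that more compound is tolerated), compound 1 `COc1ccc(-c2cc(=O)c3cc(NC(C)=O)ccc3o2)cc1` gives 226000 nM, compound 2 `CC(=O)Nc1ccc2oc(-c3ccc(F)cc3)cc(=O)c2c1` gives 203000 nM, and compound 3 `COc1ccccc1-c1cc(=O)c2cc(N)ccc2o1` gives 198000 nM; all three fall within the scatter of one another. The step of a 1.1-fold lower number from compound 1 to compound 2 (0.05 log units; within the scatter) covers the change (fluoro in place of methoxy on an aromatic carbon). Compound 4 `Nc1ccc2oc(-c3ccccc3F)cc(=O)c2c1` is not yet measured; it differs from compound 3 by fluoro in place of methoxy on an aromatic carbon. This is the same kind of change as that from compound 1 to compound 2, not the same, since there the fluoro sits para to a large group and here ortho to a large group. The difference between the two cores is not broken down here. Because a 1.1-fold lower number from compound 1 to compound 2 (0.05 log units; within the scatter) stayed within the scatter, the step of a 1.1-fold lower number from compound 3 to compound 4 (0.04 log units; within the scatter) is expected to be equally small. Compound 4 is estimated at 180000 nM, with a range from 100000 nM to 350000 nM.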

Compound 4, half-maximal cytotoxic concentration: 283000 nM
Compound 4: middle estimate off by 1.6-fold (0.20 log units), on the low side; low and high end bracket the measured number.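

In this assay the step of a 1.4-fold higher number from compound 3 to compound 4 (0.16 log units; within the scatter) joins the earlier one, and the two steps for fluoro in place of methoxy on an aromatic carbon do not differ: the same change on two cores in this assay, a 1.1-fold lower number (0.05 log units; within the scatter) from compound 1 to compound 2 and a 1.4-fold higher number (0.16 log units; within the scatter) from compound 3 to compound 4, 1.6-fold (0.20 log units) apart, within the scatter of two such steps. On these two pairs, the change therefore carries from one core to the other without a readable difference in tolerated concentration. This does not show that the change is without effect on other cores, and with only one place tested on each core, the contributions of core and place cannot be separated.

Open, from the compounds shown here alone, is how the same two groups behave at the other core's place on the ring. Also open, going by these compounds, is what a chloro, a nitrile or a carboxylic acid would give at that aromatic carbon.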